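The source may report more compounds than this note shows. Statements on the series, on what has been measured and on what is new or still open speak of the compounds shown alone.

Compound 1, `O=C(c1ccccc1)N(CCCCCCN1C[C@H](O)[C@@H](O)[C@H](O)[C@H]1CO)C1CCCCC1`: in an ADME assay on MDBK cells (Bos taurus) for cytotoxicity, read by MTT assay (on this read-out higher numbers stand for lower toxicity in this test and lower numbers for higher toxicity in this test), compound 1 gives > 500000 nM, which is a limit of the assay rather than a number.
Compound 2, `CS(=O)(=O)N(CCCCCCN1C[C@H](O)[C@@H](O)[C@H](O)[C@H]1CO)C1CCCCC1`: in this assay compound 2 gives > 500000 nM, again a limit.
Compound 3, `CC(C)(C)S(=O)(=O)N(CCCCCCN1C[C@H](O)[C@@H](O)[C@H](O)[C@H]1CO)C1CCCCC1`: in this assay compound 3 gives > 500000 nM, also a limit.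

Within the data shown here, compound 3 therefore stands where every value so far stands: at the limit of > 500000 nM in this assay, at which 3 of the 3 values shown sit. Among the measured compounds shown here, no measured compound has given a true number, so none of the three can be placed above or below another.

The next compound, compound 4, is `CC(C)(C)NC(=O)N(CCCCCCN1C[C@H](O)[C@@H](O)[C@H](O)[C@H]1CO)C1CCCCC1`. It differs from compound 3 in one place: (tert-butyl)carbamoyl in place of (tert-butyl)sulfonyl on an amine nitrogen.

Which measured steps bear on this change? The step that the two limits leave unreadable from compound 2 to compound 3 changed the group on the sulfonyl sulfur, and the steps a step that the two limits leave unreadable from compound 1 to compound 2 and a step that the two limits leave unreadable from compound 1 to compound 3 exchanged the whole group on the amine nitrogen. All three are unreadable in size because the limit of > 500000 nM in this assay, at which 3 of the 3 values shown sit, caps each of the values involved. For the measured compounds named here, they tell only that none of these exchanges brought the toxicity into the measurable range.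

On that basis compound 4 is expected to behave like compound 3, with a step of about a number no higher from compound 3 to compound 4 (the limit leaves the size open) in this assay, most likely again ending at a limit rather than a number. The estimate for compound 4 is 500000 nM, within a range from 250000 nM to 1000000 nM.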

Compound 4, half-maximal cytotoxic concentration: > 500000 nM
Compound 4: a limit, no number (the forecaster's own chance of this, stated with the estimate: 85%); the middle value sits exactly at the limit.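

Among these compounds, compound 4 also gives a limit rather than a number, so no step among compound 1, compound 2, compound 3 and compound 4 can be read in size, because all of them share one limit: the limit of > 500000 nM in this assay, at which 4 of the 4 values shown sit.

The compounds shown leave open how far these four differ in this assay and whether any change on the amine nitrogen would give a true number.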